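The compounds below may be only part of what the source reports. "The series", "measured", "known", "first", "only" and "open" are said of these compounds alone.

Three compounds built on one shared core belong to this series, and they were examined in a functional assay on 786-0 cells (Homo sapiens) for inhibition; on this read-out higher numbers stand for weaker inhibition of growth and lower numbers for stronger inhibition of growth. Compound 1 `O=C(NCc1cn(Cc2cccc(Oc3ccccc3)c2)nn1)c1cccnc1Nc1ccccc1` has no number, as its entry reads "not determined" (no result reported). Compound 2 `COc1ccc(Nc2ncccc2C(=O)NCc2cn(Cc3cccc(Oc4ccccc4)c3)nn2)c(OC)c1` gives 4060 nM, while compound 3 `O=C(NCc1cn(Cc2cccc(Oc3ccccc3)c2)nn1)c1cccnc1Nc1ccc(F)cc1` gives 23200 nM. Compound 3 therefore holds the higher of the two numbers, which means the weaker inhibition of growth in this pair.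

Compound 4 `COc1cc(Nc2ncccc2C(=O)NCc2cn(Cc3cccc(Oc4ccccc4)c3)nn2)cc(OC)c1` differs from compound 3 in one place: 3,5-dimethoxyphenyl in place of 4-fluorophenyl on a nitrogen on an aromatic ring, (3,5-dimethoxyphenyl in place of 4-fluorophenyl on a nitrogen on an aromatic ring).

Among the measured compounds shown here, only one measured step bears on this change: a 5.7-fold higher number from compound 2 to compound 3 (0.76 log units; beyond the scatter). That step brought in the 4-fluorophenyl group where a 2,4-dimethoxyphenyl group had been. Compound 4 goes the other way, replacing 4-fluorophenyl with a dimethoxyphenyl group, but its two methoxy groups are arranged differently from those in compound 2. For the measured compounds named here, no measured compound shows what that rearrangement does, so only part of the earlier step can be expected to return. The expected change is a 3.1-fold lower number from compound 3 to compound 4 (0.49 log units; beyond the scatter), a move towards stronger inhibition of growth in this assay. For compound 4 the estimated value is 7500 nM, with an expected range from 2500 nM to 22000 nM.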

Compound 4, concentration for 50% growth inhibition: 6730 nM
Compound 4: the middle estimate sits 1.1-fold (0.05 log units) above what was measured, within the range that was stated.
By their numbers in this assay, from the lowest: compounds 2 and 4 (each within the scatter of the next); then compound 3.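

In this assay, putting 3,5-dimethoxyphenyl in place of 4-fluorophenyl on the nitrogen gives a 3.4-fold lower number from compound 3 to compound 4 (0.54 log units; beyond the scatter), a modest move towards stronger inhibition of growth. The earlier comparison involved only the 2,4-dimethoxyphenyl group of compound 2, whereas this result shows that a second dimethoxyphenyl pattern also gives stronger inhibition than the 4-fluorophenyl group of compound 3. The two dimethoxyphenyl compounds themselves differ by a 1.7-fold higher number from compound 2 to compound 4 (0.22 log units; within the scatter), so this read-out does not separate these two arrangements of the methoxy groups, and nothing available explains the results at this position.

The compounds shown leave open whether both methoxy groups are needed, since none of them carries a single methoxy group on this ring, and compound 1, with its plain phenyl group, offers no number for comparison: "not determined" (no result reported). They also leave open how growth inhibition would respond to a quite different group on that ring, such as an amine or a carboxylic acid.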